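Trifluoromethyl in place of ethyl on the benzamide ring

The source may report more compounds than this note shows. Statements on the series, on what has been measured and on what is new or still open speak of the compounds shown alone.

Compound 3 `CCc1ccc(C(=O)Nc2ccc(C)c(-n3cc(-c4cccnc4)cn3)c2)cc1` gives 6520 nM in a functional assay on K562 cells (Homo sapiens) for inhibition, read by MTT assay, with a stated time of 48 h (on this read-out higher numbers stand for weaker inhibition and lower numbers for stronger inhibition), the highest of the three numbers measured. Compound 1 `Cc1ccc(NC(=O)c2cccc(C(F)(F)F)c2)cc1-n1cc(-c2cccnc2)cn1` gives 270 nM and compound 2 `Cc1ccc(NC(=O)c2cccc(Cl)c2)cc1-n1cc(-c2cccnc2)cn1` gives 1320 nM; the steps of a 24-fold higher number from compound 1 to compound 3 (1.38 log units; beyond the scatter) and a 4.9-fold higher number from compound 2 to compound 3 (0.69 log units; beyond the scatter) both lie beyond the scatter, as does a 4.9-fold higher number from compound 1 to compound 2 (0.69 log units; beyond the scatter). Compound 4 `Cc1ccc(NC(=O)c2ccc(C(F)(F)F)cc2)cc1-n1cc(-c2cccnc2)cn1` differs from compound 3 by trifluoromethyl in place of ethyl on an aromatic carbon. For the measured compounds named here, no measured step exchanges ethyl for trifluoromethyl at this place; the nearest guides are compound 1, which carries trifluoromethyl on the same ring and stands far lower, and the modest size of the halogen-for-trifluoromethyl exchange. For compound 4 a lower number is therefore expected, the step being estimated as a 4.3-fold lower number from compound 3 to compound 4 (0.64 log units; beyond the scatter). Compound 4 is estimated at 1500 nM, within 400 nM to 6000 nM.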

Compound 4, half-maximal inhibitory concentration: 760 nM
Beside the measured number, compound 4's estimate is 2.0-fold (0.30 log units) above it; the range from low to high includes it.
By their numbers in this assay, from the lowest: compound 1; then compounds 4 and 2 (each within the scatter of the next); then compound 3.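

In this assay the direct exchange at the place para to a large group reads an 8.6-fold lower number from compound 3 to compound 4 (0.93 log units; beyond the scatter) and so shows that trifluoromethyl there, not only at the other ring position of compound 1, lowers the number. Moving the trifluoromethyl still counts, with a 2.8-fold higher number from compound 1 to compound 4 (0.45 log units; beyond the scatter) as the step between the two placements. The step of a 1.7-fold lower number from compound 2 to compound 4 (0.24 log units; within the scatter) stays within the scatter. Nothing measured here explains these differences. The compounds shown leave open how an amine, a methoxy group or a longer chain would read at this place.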